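The source may report more compounds than this note shows. Statements on the series, on what has been measured and on what is new or still open speak of the compounds shown alone.

Of the compounds shown here, two of a shared core have been measured in a functional assay on SMMC-7721 cells (Homo sapiens) for cytotoxicity, read by MTT assay, with a stated time of 72 h; on this read-out lower numbers stand for stronger inhibition and higher numbers for weaker inhibition. Compound 1, with the structure `COc1ccc2c(c1)[n+]([O-])nc(NCOCc1ccccc1)[n+]2[O-]`, gives in this assay 21400 nM. Compound 2, with the structure `CCCCCOCNc1n[n+]([O-])c2ccccc2[n+]1[O-]`, gives in this assay 17000 nM. Compound 2 holds the lower of the two numbers, but the gap to compound 1 lies within the scatter of repeated measurements, so the two compounds cannot be told apart on these readings.

Compound 3, with the structure `CCOCNc1n[n+]([O-])c2ccccc2[n+]1[O-]`, is not yet measured. The change from compound 2 to compound 3 is a single one: hydrogen in place of propyl on a saturated chain carbon, two bonds along the chain from an oxygen on a saturated carbon. The pentyloxy chain of compound 2 is thereby cut back to an ethoxy chain, with nothing else altered in the core.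

Among the compounds with values here, no measured pair shows what shortening this chain does, so the expectation rests only on the reading of compound 2. The shift from compound 2 to compound 3 in this assay is estimated as a 1.5-fold higher number from compound 2 to compound 3 (0.17 log units; within the scatter), a step that may not rise above the scatter. Compound 3 is therefore expected to give about 25000 nM in this assay, somewhere between 10000 nM and 60000 nM.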

Compound 3, half-maximal inhibitory concentration: 27100 nM
Compound 3: middle estimate off by 1.1-fold (0.04 log units), on the low side; low and high end bracket the measured number.
By their numbers in this assay, from the lowest: compounds 2, 1 and 3 (each within the scatter of the next).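

In this assay, within the data shown here, cutting the pentyloxy chain back to ethoxy gives a 1.6-fold higher number from compound 2 to compound 3 (0.20 log units; within the scatter), and this is the first direct reading of what shortening this chain does. Hydrogen in place of propyl at this position, on a saturated chain carbon, two bonds along the chain from an oxygen on a saturated carbon, therefore leaves compound 2 and compound 3 indistinguishable on this read-out, so this loss of chain length produces no change that can be separated from the ordinary variation between repeated measurements. No supporting information is available that could explain this result.

The pentyloxy and ethoxy chains alone cannot show whether chain length matters at all at this position, as a single step within the scatter gives no trend. On these data alone, it remains open whether a longer chain, such as octyloxy, or a chain ending in an amine or a carboxylic acid, would move the reading in this assay clearly away from those of compound 2 and compound 3.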